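The source may report more compounds than this note shows. Statements on the series, on what has been measured and on what is new or still open speak of the compounds shown alone.

Measured so far in a functional assay on A549 cells (Homo sapiens) for cytotoxicity, read by MTT assay, with a stated time of 72 h; on this read-out higher numbers stand for weaker inhibition and lower numbers for stronger inhibition:

compound 1 `Cc1cc(=O)n(-c2ccc(Br)cc2F)nc1C(=O)Nc1ccc(Oc2ncnc3ccsc23)c(F)c1` gives 2980 nM
compound 2 `Cc1cc(=O)n(-c2ccccc2C(F)(F)F)nc1C(=O)Nc1ccc(Oc2ncnc3sccc23)c(F)c1` gives 16300 nM

Compound 2 stands at the higher of the two numbers; compound 1 sits lower, and the gap between them lies beyond the usual scatter. For the measured compounds named here, the two compounds differ in more than one place, so no single structural step between measured compounds is isolated here.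

Compound 3 `Cc1cc(=O)n(-c2ccc(Br)cc2F)nc1C(=O)Nc1ccc(Oc2ncnc3sccc23)c(F)c1` differs from compound 2 in one place: 4-bromo-2-fluorophenyl in place of 2-(trifluoromethyl)phenyl on an aromatic nitrogen. Going by the values given here, the remainder of compound 3 is that of compound 2, while the entering group is the one carried by compound 1.

A downward step is expected here, because compound 1 with the same 4-bromo-2-fluorophenyl gives 2980 nM. The step in this assay from compound 2 to compound 3 is estimated as a 3.6-fold lower number from compound 2 to compound 3 (0.56 log units; beyond the scatter). Compound 3 is expected to come in near 4500 nM, with a range of 1500 nM to 14000 nM.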

Compound 3, half-maximal inhibitory concentration: 11500 nM
Compound 3: the middle estimate sits 2.6-fold (0.41 log units) below what was measured, within the range that was stated.
By their numbers in this assay, from the lowest: compound 1; then compounds 3 and 2 (each within the scatter of the next).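

In this assay, 4-bromo-2-fluorophenyl in place of 2-(trifluoromethyl)phenyl on the aromatic nitrogen amounts to a 1.4-fold lower number from compound 2 to compound 3 (0.15 log units; within the scatter), so on this core the two aryl groups cannot be told apart at this position. With 4-bromo-2-fluorophenyl held fixed, exchanging one group of 9 heavy atoms for the other on the oxygen gives a 3.9-fold higher number from compound 1 to compound 3 (0.59 log units; beyond the scatter), so in these compounds the step beyond the scatter lies at that oxygen-linked group and not at the aromatic nitrogen. No measurement at hand bears on either step.

Open, from the compounds shown here alone, is whether a non-aromatic group on the aromatic nitrogen, such as cyclohexyl or a longer alkyl chain, would give a step beyond the scatter. Also open, going by these compounds, is whether the step at the oxygen-linked group holds with 2-(trifluoromethyl)phenyl on the nitrogen.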